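This account rests on a few compounds, and the source may have more. Where it says the series, first, only, none or still open, it means among the compounds named here.

Compound 1 `O=C1/C(=C/c2ccccc2F)CN(C(=S)SCc2cn(Cc3ccccc3Cl)nn2)C/C1=C\c1ccccc1F` is the starting point of this set: in a functional assay on MDA-MB-231 cells (Homo sapiens) for cytotoxicity, read by MTT assay, with a stated time of 24 h (on this read-out lower numbers stand for stronger inhibition and higher numbers for weaker inhibition), compound 1 gives 100000 nM. Compound 2 `O=C1/C(=C/c2ccccc2F)CN(C(=S)SCc2cn(Cc3ccccc3F)nn2)C/C1=C\c1ccccc1F` keeps everything else and carries the change (fluoro in place of chloro on an aromatic carbon); in this assay compound 2 gives 57600 nM. The step of a 1.7-fold lower number from compound 1 to compound 2 (0.24 log units; within the scatter) is small, and it is not read here as a real shift. Compound 3 `COc1ccc(/C=C2\CN(Cc3cn(Cc4ccccc4Cl)nn3)C/C(=C\c3ccc(OC)cc3)C2=O)cc1` rests on a different core; how that core differs from the core of compound 1 is not broken down here. For compound 3 in this assay only a limit of the assay is known, > 100000 nM, and compound 3 sits at the limit of > 100000 nM in this assay, at which 1 of the 3 values shown sits. Compound 4 `COc1ccc(/C=C2\CN(Cc3cn(Cc4ccccc4F)nn3)C/C(=C\c3ccc(OC)cc3)C2=O)cc1` has not been measured; it differs from compound 3 by fluoro in place of chloro on an aromatic carbon, the same change that links compound 1 to compound 2, at the same place. Since compound 1 and compound 2 show that this change moves the number by a 1.7-fold lower number from compound 1 to compound 2 (0.24 log units; within the scatter), the expected step of a number no higher from compound 3 to compound 4 (the limit leaves the size open) is likewise small. Compound 4 is therefore expected to give about 100000 nM in this assay, estimated between 40000 nM and 250000 nM, most likely as a limit again.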

Compound 4, half-maximal inhibitory concentration: 67200 nM
Compound 4: middle estimate off by 1.5-fold (0.17 log units), on the high side, and the stated range covers the measured number.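

Replacing 2-chlorobenzyl with 2-fluorobenzyl on the core of compound 3 gives an at least 1.4-fold lower number from compound 3 to compound 4 (0.17 log units; that floor lies within the scatter), and in this assay this step can be set beside the one on the core of compound 1: the same change on two cores in this assay, a 1.7-fold lower number (0.24 log units; within the scatter) from compound 1 to compound 2 and an at least 1.4-fold lower number (0.17 log units; that floor lies within the scatter) from compound 3 to compound 4; the limit leaves it open whether they differ. Compound 3 is known only as a limit of the assay, > 100000 nM. The change therefore shows no step beyond the scatter on the core of compound 1 and only a floor within the scatter on the core of compound 3, which does not fix the true size of the second step or show that the two steps are equal.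

The compounds shown leave open whether a different group at this place on the aromatic ring, such as an amine, a carboxylic acid or a methoxy group, would move the number beyond the scatter on either core. They also leave open how a bromo group or a plain benzyl group without any halogen would read in this assay.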